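Amide chain length in a thiazolidine carboxamide series

The source may hold more compounds than are shown below. What is called first, only, known or untested is meant among the compounds shown, and "the series" means these compounds.

Compounds 1 and 2 share one core and differ only in the amide chain: compound 1 `CCCCCCCCNC(=O)[C@@H]1CSC(c2cc(OC)c(OC)c(OC)c2)N1` and compound 2 `CCCCCCCCCCNC(=O)[C@@H]1CSC(c2cc(OC)c(OC)c(OC)c2)N1`. In an ADME assay on cells (Fibroblast, Homo sapiens) for antiproliferative activity, read by sulforhodamine B assay, with a stated time of 48 h (on this read-out lower numbers stand for stronger inhibition and higher numbers for weaker inhibition), compound 1 gives 20800 nM and compound 2 gives 6700 nM. The change ethyl in place of hydrogen on a saturated chain carbon, eight bonds along the chain from an amide-type nitrogen produced a 3.1-fold lower number from compound 1 to compound 2 (0.49 log units; beyond the scatter). Compound 3 `CCCCCCCCCCCCNC(=O)[C@@H]1CSC(c2ccc(OC)c(OC)c2)N1` carries a different core; how its core differs from that of compound 1 is not broken down here. In this assay compound 3 gives 4500 nM, a number within the scatter of compound 2 and beyond the scatter of compound 1.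

Compound 4 `CCCCCCCCCCCCCCNC(=O)[C@@H]1CSC(c2ccc(OC)c(OC)c2)N1` is not yet measured. It differs from compound 3 by ethyl in place of hydrogen on a saturated chain carbon, ten or more bonds along the chain from an amide-type nitrogen, the same kind of change as that from compound 1 to compound 2, though at a different place on the chain. A smaller gain than the earlier step is expected, because a 3.1-fold lower number from compound 1 to compound 2 (0.49 log units; beyond the scatter) came at a shorter chain and compound 2 and compound 3 already sit within the scatter of each other. For compound 4 the expected step is a 1.5-fold lower number from compound 3 to compound 4 (0.18 log units; within the scatter), giving an estimate of 3000 nM, with a range from 1200 nM to 8000 nM.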

Compound 4, half-maximal inhibitory concentration: 2800 nM
Compound 4: the middle estimate sits 1.1-fold (0.03 log units) above what was measured; measured number inside the range.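

In this assay, ethyl in place of hydrogen on a saturated chain carbon gives a 1.6-fold lower number from compound 3 to compound 4 (0.21 log units; within the scatter), so this step alone does not establish a gain on the core of compound 3. Set beside the earlier step on the core of compound 1, the new step shows no difference larger than two such steps can differ by chance: the same change on two cores in this assay, a 3.1-fold lower number (0.49 log units; beyond the scatter) from compound 1 to compound 2 and a 1.6-fold lower number (0.21 log units; within the scatter) from compound 3 to compound 4, 1.9-fold (0.29 log units) apart, within the scatter of two such steps. Among these compounds, the change is therefore compatible with carrying over from one core to the other, but this does not show that its effect is the same on both, as each core offers only one pair and the two steps lie at different places on the chain.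

Open, as far as these compounds go, is whether a chain longer than that of compound 4 would give a number beyond the scatter of compound 4, and how the two cores compare at one and the same chain length. Also open, from the compounds shown here alone, is what an amine or a carboxylic acid at the far end of the chain would give.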